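Sulfur for oxygen at the carbonyl carbon of compound 3

The source may report more compounds than this note shows. Statements on the series, on what has been measured and on what is new or still open speak of the compounds shown alone.

Of the compounds shown here, three on a shared core have been tested in a functional assay on CHO-K1 cells for agonist activity at Glucose-dependent insulinotropic receptor (Homo sapiens), read by a luciferase reporter, with a stated time of 5 h; on this read-out lower numbers stand for an effect already at smaller amounts and higher numbers for an effect only at larger amounts of compound. Compound 1 `CC(C)OC(=O)N1CCC(Oc2ncnc3c2CCN3c2ccc(C#N)cc2F)CC1` gives 63.1 nM. Compound 2 `CCCOC(=O)N1CCC(Oc2ncnc3c2CCN3c2ccc(S(C)(=O)=O)cc2F)CC1` gives 79.4 nM, and compound 3 `CC(C)COC(=O)N1CCC(Oc2ncnc3c2CCN3c2ccc(S(C)(=O)=O)cc2F)CC1` gives 25.1 nM. Compound 3 therefore stands lowest of the three numbers, separated from each of the others by more than the scatter. Going by the values given here, the only step between two measured compounds that differ in a single place is a 3.2-fold lower number from compound 2 to compound 3 (0.50 log units; beyond the scatter), where the alkyl chain of the carbamate-type side group was branched.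

Compound 4 `CC(C)SC(=O)N1CCC(Oc2ncnc3c2CCN3c2ccc(S(C)(=O)=O)cc2F)CC1` is the next step from compound 3: isopropylsulfanyl in place of isobutoxy on a carbonyl carbon. Among the compounds with values here, no measured pair shows oxygen exchanged for sulfur at this carbonyl carbon, so the step from compound 2 to compound 3 is the only related evidence, and it concerned the shape of the chain rather than the atom that joins it to the carbonyl. With branching retained but the chain shortened and the linking atom exchanged, the change is expected to move the number little, if at all, beyond the scatter. Compound 4 is thus estimated at 40 nM, with a range from 15 nM to 110 nM, which amounts to an expected step of a 1.6-fold higher number from compound 3 to compound 4 (0.20 log units; within the scatter).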

Compound 4, half-maximal effective concentration: 10 nM
The estimate for compound 4 lay 4.0-fold (0.60 log units) above the measured number; measured number below the stated range.
By their numbers in this assay, from the lowest: compound 4; then compound 3; then compounds 1 and 2 (each within the scatter of the next).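

Exchanging isobutoxy for isopropylsulfanyl on the carbonyl carbon gives a 2.5-fold lower number from compound 3 to compound 4 (0.40 log units; beyond the scatter) in this assay, so a sulfur-linked group with a shorter chain is accepted at this position and carries a lower number than the isobutoxy group. Against propoxy, the same kind of exchange gives a 7.9-fold lower number from compound 2 to compound 4 (0.90 log units; beyond the scatter), so the range seen at this carbonyl carbon, which earlier rested only on the shape of an oxygen-linked chain, widens once the linking atom changes as well. Nothing at hand explains why the number falls with this change.

The linking atom and the chain change together on the way to compound 4, so the compounds shown cannot divide the step between the sulfur and the chain; isobutylsulfanyl on the same carbonyl carbon would separate the two. Going by these compounds, it also stays open whether a nitrogen-linked group such as isopropylamino would behave in the same way, and whether the gain from isopropylsulfanyl would carry over to a compound with nitrile in place of methylsulfonyl, the group compound 1 carries.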